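Alkynyl chain extension on the amine substituent: compound 4

A few compounds are considered here, and "the series" means these few. Any claim that something is new, unique, unknown or untested is made for them only; others in the source may bear on it.

The series shares the core of compound 1 `CCCN(CC[C@H](N)C(=O)O)C[C@H]1O[C@@H](n2cnc3c(N)ncnc32)[C@H](O)[C@@H]1O`, which carries an ethyl group on the saturated chain carbon bound to the amine nitrogen. In an assay for inhibition of tRNA (cytosine(38)-C(5))-methyltransferase (Homo sapiens), with a stated time of 5 min, tested at 100 uM (a lower number here means less inhibition, a higher number more inhibition at the concentration tested (going by the name of the read-out)), compound 1 has no result reported, so it stands without a number of its own. Compound 2 `Nc1ncnc2c1ncn2[C@@H]1O[C@H](CN(CC[C@H](N)C(=O)O)CC2CCCC2)[C@@H](O)[C@H]1O`, with cyclopentyl at the same position, gives 24.5% in this assay. Compound 3 `CC#CCN(CC[C@H](N)C(=O)O)C[C@H]1O[C@@H](n2cnc3c(N)ncnc32)[C@H](O)[C@@H]1O`, with prop-1-yn-1-yl there, gives 61.3%. Among the measured compounds shown here, the one step that bears on the change at hand is a number 36.8 percentage points higher from compound 2 to compound 3 (beyond the scatter), which shows that the inhibition in this assay is higher with prop-1-yn-1-yl at this position than with cyclopentyl. Compound 4 `CCC#CCN(CC[C@H](N)C(=O)O)C[C@H]1O[C@@H](n2cnc3c(N)ncnc32)[C@H](O)[C@@H]1O` differs from compound 1 as follows: but-1-yn-1-yl in place of ethyl on a saturated chain carbon bound to an amine nitrogen. For the measured compounds named here, no measured step connects ethyl to an alkynyl group directly, so the expectation rests on compound 3 and the step from compound 2 to compound 3. Compound 4 is therefore expected to show inhibition near the level of compound 3, with its estimate in this assay placed at 55%, between 30% and 80%.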

Compound 4, a percentage reported as inhibition, at one concentration (the size of the read-out at that concentration, not a potency): 62.8%
Compound 4: middle estimate off by 7.8 percentage points, on the low side; low and high end bracket the measured number.
By their numbers in this assay, from the lowest: compound 2; then compounds 3 and 4 (each within the scatter of the next).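

In this assay, the methyl group added to the alkynyl chain gives a number 1.5 percentage points higher from compound 3 to compound 4 (within the scatter), so lengthening the chain from compound 3 leaves the inhibition unchanged within the usual scatter. Among the compounds shown here, replacing cyclopentyl with but-1-yn-1-yl gives a number 38.3 percentage points higher from compound 2 to compound 4 (beyond the scatter), a large step of the same direction as the one to compound 3. Both alkynyl compounds with numbers therefore stand clear of compound 2, and the link to higher inhibition now rests on two alkynyl groups rather than one.

Open, as far as these compounds go, are where the ethyl group of compound 1 stands against the alkynyl groups, and whether a longer chain, an amine or a carboxylic acid at this position would keep the inhibition. Nothing shown gives a measured reason for the difference between the alkynyl groups and cyclopentyl.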